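Swapping the chain amine of compound 3 for methylpiperazine

A few compounds are considered here, and "the series" means these few. Any claim that something is new, unique, unknown or untested is made for them only; others in the source may bear on it.

Compound 1 `COc1cc2oc(-c3ccccc3)cc(=O)c2c(O)c1OCCCN1CCCCC1`: in a functional assay on HepG2 cells (Homo sapiens) for antiproliferative activity, read by MTT assay, with a stated time of 48 h (on this read-out lower numbers stand for stronger inhibition and higher numbers for weaker inhibition), compound 1 gives 22300 nM.
Compound 2 `O=c1cc(-c2ccccc2)oc2cc(O)c(OCCCCN3CCCCC3)c(O)c12`: compound 2 reaches only the assay limit, > 100000 nM.
Compound 3 `CCN(CC)CCCCOc1c(OC)cc2oc(-c3ccccc3)cc(=O)c2c1O`: in this assay compound 3 gives 7100 nM.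

Compound 3 has the lowest number of the two measured on this read-out; compound 1 sits above it by a 3.1-fold lower number from compound 1 to compound 3 (0.50 log units; beyond the scatter) read the other way. Compound 4 `COc1cc2oc(-c3ccccc3)cc(=O)c2c(O)c1OCCCN1CCN(C)CC1` differs from compound 3 by 4-methylpiperazin-1-yl in place of (diethylamino)methyl on a saturated chain carbon, three bonds along the chain from an oxygen on an aromatic ring. Among the measured compounds shown here, the one measured step at this spot is a 3.1-fold lower number from compound 1 to compound 3 (0.50 log units; beyond the scatter), where opening the ring amine into an open-chain amine lowered the number. Compound 4 returns to a ring amine, so the number is expected to move back up, by about a 2.8-fold higher number from compound 3 to compound 4 (0.45 log units; beyond the scatter). Compound 4 is therefore estimated at 20000 nM, most likely between 7000 nM and 60000 nM.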

Compound 4, half-maximal inhibitory concentration: 15100 nM
For compound 4 the middle estimate is 1.3-fold (0.12 log units) above the measured one; the range from low to high includes it.
By their numbers in this assay, from the lowest: compound 3; then compounds 4 and 1 (each within the scatter of the next). At a limit, above all of these: compound 2.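

Replacing the open-chain amine with 4-methylpiperazin-1-yl raises the number (a 2.1-fold higher number from compound 3 to compound 4 (0.33 log units; beyond the scatter)), which gives a second ring amine that sits higher than compound 3. The two ring amines cannot be told apart (a 1.5-fold lower number from compound 1 to compound 4 (0.17 log units; within the scatter)), so the second ring nitrogen and its methyl group make no difference that can be read here. Among these chain amines, only the diethylamino group of compound 3 stands apart.

As far as these compounds go, whether a smaller open-chain amine such as dimethylamino, or a morpholine ring, would follow compound 3 or the ring amines remains open. Nothing measured here explains why the open-chain amine gives the lower number.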